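This account rests on a few compounds, and the source may have more. Where it says the series, first, only, none or still open, it means among the compounds named here.

Measured compounds:
- compound 1 `CC(=O)NCCN(C)c1cccc(OCCCCCCNC(=O)Oc2cccc(-c3ccccc3)c2)c1`: in a functional assay on cells for agonist activity at melatonin receptor type 1B (Homo sapiens), read by GTPgammaS binding, with a stated time of 30 min (on this read-out lower numbers stand for smaller maximal responses and higher numbers for larger maximal responses), compound 1 gives 0.75
- compound 2 `CC(=O)NCCN(C)c1cccc(OCCCCOc2cccc(OC(=O)NC3CCCCC3)c2)c1`: in this assay compound 2 gives 0.05
- compound 3 `CC(=O)NCCN(C)c1cccc(OCCCCNC(=O)Oc2cccc(-c3ccccc3)c2)c1`: in this assay compound 3 gives 0.39

Among these three, compound 2 stands lowest: its value lies beyond the usual scatter under that of compound 3, and further still under that of compound 1, so compound 2 produces the smallest maximal response of the set.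

The step to compound 4 `CC(=O)NCCN(C)c1cccc(OCCCCOc2cccc(O)c2)c1` leaves the shared core untouched and changes only the outer end: hydrogen in place of cyclohexylcarbamoyl on an oxygen on an aromatic ring. The cyclohexylcarbamoyl group is removed in full and the oxygen on the aromatic ring is left bearing a hydrogen, that is, the (cyclohexylcarbamoyl)oxy group becomes a hydroxy group.

Nothing measured here shows what the hydroxy end does on its own. Since compound 2 already sits near the bottom of the scale, little room remains for a downward move, and a small upward move is the more likely outcome; the step from compound 2 to compound 4 in this assay is expected to be a number 0.070 higher from compound 2 to compound 4 (within the scatter), which lies within the scatter. Compound 4 is therefore estimated at 0.12, with a range from 0 to 0.4.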

Compound 4, intrinsic activity: the largest response reached, as a fraction of the reference agonist's: 0.18
Estimate against measurement, compound 4: 0.060 below, and the stated range covers the measured number.
By their numbers in this assay, from the lowest: compound 2; then compound 4; then compound 3; then compound 1.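

In this assay, taking the cyclohexylcarbamoyl group off the oxygen on the aromatic ring and leaving a hydroxy group gives a number 0.13 higher from compound 2 to compound 4 (beyond the scatter), a modest rise in the maximal response. Among the compounds shown here, this pair gives the first direct reading of this position: the response does not depend on the cyclohexylcarbamoyl group, since it persists and even rises slightly once the whole group is gone. Nothing available explains why the response moves in this direction.

Still open, going by these compounds, is whether a methyl group on the same oxygen, or a phenylcarbamoyl group in place of the cyclohexylcarbamoyl, would give a response closer to that of the hydroxy compound or to that of the carbamate. A single pair also cannot tell whether this change would have the same effect in other compounds.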